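Solubility across the quinolyl-oxy acetamide set and a demethyl analogue

The compounds below may be only part of what the source reports. "The series", "measured", "known", "first", "only" and "open" are said of these compounds alone.

Three compounds of the series have a number in a physicochemical assay for solubility, read by chemiluminescence, measured as kinetic solubility (a higher number here means a more soluble compound, a lower number a less soluble compound), so far. Compound 1 `Cc1cc(C)cc(NC(=O)COc2ccnc3ccccc23)c1` gives 59000 nM in this assay. Compound 2 `COc1ccc2nc(C)nc(OCC(=O)Nc3cc(C)cc(C)c3)c2c1` gives 3000 nM in this assay. Compound 3 `COc1ccc2nc(C)cc(OCC(=O)Nc3cc(C)cc(C)c3)c2c1` gives 26000 nM in this assay and stands second highest of the three numbers; its nearest neighbour is compound 1, whose number is higher by a margin beyond the scatter, and its furthest is compound 2, whose number is lower by a margin well beyond the scatter.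

Compound 4 `COc1ccc2nccc(OCC(=O)Nc3cc(C)cc(C)c3)c2c1` has not yet been measured in this assay. From compound 3 it differs by hydrogen in place of methyl on an aromatic carbon. Within the data shown here, no measured pair in the set shows this exact change, so the size of the step has to be guessed. A small upward step, at or just beyond the scatter, is expected: compound 1, which also lacks a methyl on the shared core, gives 59000 nM in this assay. The step from compound 3 to compound 4 is therefore expected to be a 1.3-fold higher number from compound 3 to compound 4 (0.13 log units; within the scatter). For compound 4 the estimate in this assay is 35000 nM, with a range from 15000 nM to 80000 nM.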

Compound 4, solubility: 51000 nM
Compound 4: middle estimate off by 1.5-fold (0.16 log units), on the low side, and the stated range covers the measured number.
By their numbers in this assay, from the lowest: compound 2; then compounds 3, 4 and 1 (each within the scatter of the next, the first and the last beyond it).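

In this assay, the change at the aromatic carbon next to the ring nitrogen can now be read directly: hydrogen in place of methyl gives a 2.0-fold higher number from compound 3 to compound 4 (0.29 log units; within the scatter), so on this pair the step stays inside the scatter. Methoxy in place of hydrogen on an aromatic carbon of the shared core gives a 1.2-fold lower number from compound 1 to compound 4 (0.06 log units; within the scatter), so this single change also stays inside the scatter. Nothing available bears on the reason for either step.

From the compounds shown here alone, at this position only methyl and hydrogen are compared, so the outcome with an amine, a carboxylic acid or a longer chain remains open. Going by these compounds, each step also rests on a single pair, so whether either holds on other members remains open too.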